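Ketone chain variation on a shared diaryl ether acid core

The source may report more compounds than this note shows. Statements on the series, on what has been measured and on what is new or still open speak of the compounds shown alone.

compound 1 `CCC(=O)c1ccc(OCCCCOc2ccc(F)c(C(=O)O)c2)c(C)c1O` 124 nM
compound 2 `Cc1c(OCCCCOc2ccc(C(=O)O)cc2)ccc(C(=O)CC2CCCC2)c1O` 824 nM
compound 3 `CCCC(=O)c1ccc(OCCCCOc2cc(C(=O)O)ccc2OC)c(C)c1O` 103 nM

In an assay on HEK293 cells for positive allosteric modulation of metabotropic glutamate receptor 2 (Rattus norvegicus), read by thallium flux, with a stated time of 2.5 min (on this read-out higher numbers stand for an effect only at larger amounts of compound and lower numbers for an effect already at smaller amounts), compound 1 gives 124 nM, the second highest of the three numbers. Compound 3 at 103 nM lies within the scatter of compound 1, whereas compound 2 at 824 nM lies beyond the scatter on the higher side. Among the compounds with values here, no two measured compounds differ in a single place, so no measured step is available. Compound 4 `Cc1c(OCCCCOc2ccc(F)c(C(=O)O)c2)ccc(C(=O)CC(C)C)c1O` differs from compound 1 by isopropyl in place of methyl on a saturated chain carbon bound to a carbonyl carbon. Within the data shown here, the only measured compound with a longer ketone chain, compound 2, also carries a different acid ring, so its higher number cannot be assigned to the chain alone. Compound 4 is expected to show a step to a slightly higher number, at the edge of the scatter, of a 1.8-fold higher number from compound 1 to compound 4 (0.25 log units; within the scatter). The estimate for compound 4 is 220 nM, expected to fall between 80 nM and 650 nM.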

Compound 4, half-maximal effective concentration: 153 nM
For compound 4 the middle estimate is 1.4-fold (0.16 log units) above the measured one; the range from low to high includes it.
By their numbers in this assay, from the lowest: compounds 3, 1 and 4 (each within the scatter of the next); then compound 2.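

This gives the series its first single-place comparison: in this assay, isopropyl in place of methyl on a saturated chain carbon bound to a carbonyl carbon gives a 1.2-fold higher number from compound 1 to compound 4 (0.09 log units; within the scatter). Going from propanoyl to isobutylcarbonyl at this position therefore brings no step beyond the scatter, and the higher number of compound 2 stays unassigned. No measurement available gives a reason for this result.

Open, on these data alone, is whether an amine or a hydroxyl on this chain carbon, or a longer chain such as hexanoyl, would also stay within the scatter of compound 1.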